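Replacing a Phenyl Group with Isopropyl on Compound 3

The source may hold more compounds than are shown below. What is called first, only, known or untested is meant among the compounds shown, and "the series" means these compounds.

In a physicochemical assay for solubility, with a stated time of 18 h, at pH 7.4 (a lower number here means a less soluble compound, a higher number a more soluble compound), compound 3 `COc1ccc(F)cc1CNCCCNc1ccnc2cc(Cc3cccc(C(F)(F)F)c3)ccc12` gives 4200 nM as its reading. Compound 1 `COc1ccc(F)cc1CNCCCNc1ccnc2cc(Cc3ccc(F)cc3Cl)ccc12` gives 4200 nM as its reading, which amounts to no change at the digits printed from compound 1 to compound 3 (within the scatter) when the two are set side by side. Compound 2 `COc1ccc(-c2ccc3c(NCCCNCc4cc(F)ccc4OC)ccnc3c2)cc1` stands apart at 32000 nM and leaves compound 3 sharing the low end of these three numbers with compound 1.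

Compound 4 `COc1ccc(F)cc1CNCCCNc1ccnc2cc(CC(C)C)ccc12` differs from compound 3 in one place (isopropyl in place of 3-(trifluoromethyl)phenyl on a saturated chain carbon bound to an aromatic carbon): isopropyl stands in place of 3-(trifluoromethyl)phenyl on a saturated chain carbon bound to an aromatic carbon.

For the measured compounds named here, the closest precedent, one substituted phenyl exchanged for another on that carbon, gave no change at the digits printed from compound 1 to compound 3 (within the scatter) but kept a ring there. The larger moves are a 7.6-fold higher number from compound 1 to compound 2 (0.88 log units; beyond the scatter) and a 7.6-fold lower number from compound 2 to compound 3 (0.88 log units; beyond the scatter) and both are modest. Each exchanges a substituted benzyl and 4-methoxyphenyl on an aromatic carbon. Going by the values given here, no measured compound lacks a ring in this group, so any forecast is a stretch. Compound 2 alone departs from a substituted benzyl, and its 32000 nM reading is the higher one. A modest rise is therefore expected, with a 2.4-fold higher number from compound 3 to compound 4 (0.38 log units; beyond the scatter) as the estimated step. Compound 4 is estimated at 10000 nM with an expected range from 3500 nM to 30000 nM when it is measured.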

Compound 4, solubility: 4200 nM
Compound 4: the middle estimate sits 2.4-fold (0.38 log units) above what was measured; the measured number falls inside the stated range.
By their numbers in this assay, from the lowest: compounds 1, 3 and 4 (each within the scatter of the next); then compound 2.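

In this assay, the step from a ring to isopropyl gives no change at the digits printed from compound 3 to compound 4 (within the scatter) and the matching exchange from the other starting point gives no change at the digits printed from compound 1 to compound 4 (within the scatter) for the same place, a saturated chain carbon bound to an aromatic carbon. The earlier compounds had only shown one substituted phenyl taking the place of another there, whereas this result shows that isopropyl, a group with no ring, replacing 3-(trifluoromethyl)phenyl, also leaves the reading within the scatter. Compound 2 still stands apart, with a 7.6-fold lower number from compound 2 to compound 4 (0.88 log units; beyond the scatter) when its 4-methoxyphenyl gives way to isobutyl, and no separate measurement bears on what lies behind any of these readings.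

Whether an amine or a carboxylic acid on that same saturated chain carbon would shift the reading remains open, since the groups shown there are only substituted phenyl rings and isopropyl. Also open, from the compounds shown here alone, is whether the higher reading of compound 2 belongs to the methoxy group itself, which an unsubstituted phenyl on the same aromatic carbon could help to separate.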